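The source may hold more compounds than are shown below. What is called first, only, known or untested is meant among the compounds shown, and "the series" means these compounds.

Three compounds of one shared core have been tested in a functional assay on cells (Neutrophil, Rattus norvegicus, strain Sprague-Dawley) for inhibition; a higher number here means a weaker inhibitor, a lower number a stronger inhibitor:

compound 1, `O=C/C=C/c1ccccc1OCc1ccc(Cl)cc1`, 7400 nM
compound 2, `O=C/C=C/c1ccccc1OCc1ccccc1F`, 3300 nM
compound 3, `O=C/C=C/c1ccccc1OCc1cccc(F)c1`, 4500 nM

Among these, compound 1 returns the highest number in this assay. The gap to compound 3 lies within the usual scatter of repeated measurements, so nothing separates the two; the gap to compound 2 is somewhat larger and falls just beyond that scatter. For the measured compounds named here, all three numbers sit in a narrow band, and none of the three pairs differ in only one place, so no single-point step has been measured.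

Compound 4, `COc1ccc(COc2ccccc2/C=C/C=O)cc1`, has not yet been measured in this assay. It differs from compound 1 by methoxy in place of chloro on an aromatic carbon, the group sitting para to a large group on the benzyl ring. Going by the values given here, with no measured step to lean on, the step from compound 1 to compound 4 is expected to be small, of a size that would not stand out from the scatter, and its direction is uncertain; the estimate is a 1.2-fold lower number from compound 1 to compound 4 (0.09 log units; within the scatter). For compound 4 the expected value in this assay is 6000 nM, in a range from 2000 nM to 18000 nM.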

Compound 4, half-maximal inhibitory concentration: 3800 nM
Compound 4: middle estimate off by 1.6-fold (0.20 log units), on the high side; low and high end bracket the measured number.
By their numbers in this assay, from the lowest: compounds 2, 4, 3 and 1 (each within the scatter of the next, the first and the last beyond it).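

The series now has its first step in a single place: in this assay, methoxy in place of chloro gives a 1.9-fold lower number from compound 1 to compound 4 (0.29 log units; within the scatter). At this place, on an aromatic carbon para to a large group, the two groups therefore cannot be told apart in this assay, even though methoxy brings a hydrogen-bond acceptor that chloro lacks. No measured property of these groups is available to bear on this result.

The compounds shown leave open whether any group at this place can move the number beyond the scatter, for instance an amine, a carboxylic acid or a longer chain such as butoxy. They also leave open how the plain hydrogen compares at this place, which would give both chloro and methoxy a common reference.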